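This account rests on a few compounds, and the source may have more. Where it says the series, first, only, none or still open, it means among the compounds named here.

Measured in a functional assay on the whole organism (strain Sprague-Dawley) with Rattus norvegicus as the target, read by paw edema, with a stated time of 5 h, at a dose of 50 mg/kg by the oral route (a lower number here means less inhibition, a higher number more inhibition at the dose given (going by the name of the read-out)), so far:

compound 1, `CSc1ncc(-c2ccc(S(C)(=O)=O)cc2)n1-c1ccc(Cl)cc1`, gives 42.7%
compound 2, `CCSc1ncc(-c2ccc(S(C)(=O)=O)cc2)n1-c1ccc(Cl)cc1`, gives 52.7%
compound 3, `CCSc1ncc(-c2ccc(S(C)(=O)=O)cc2)n1-c1ccc(Br)cc1`, gives 59%

Compound 1 holds the lowest of the three numbers. Its nearest neighbour is compound 2, the step of a number 10 percentage points higher from compound 1 to compound 2 (within the scatter), which lies within the scatter; the step of a number 6.3 percentage points higher from compound 2 to compound 3 (within the scatter) also lies within the scatter. Only the gap between compound 1 and compound 3 falls beyond it.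

Compound 4, `COc1ccc(-n2c(-c3ccc(S(C)(=O)=O)cc3)cnc2SC)cc1`, has not been measured. It differs from compound 1 in one place: methoxy in place of chloro on an aromatic carbon. Neither measured step is this change. The step from compound 2 to compound 3 exchanges one halogen for another on an aromatic carbon and stayed within the scatter; the step from compound 1 to compound 2 sits on the saturated chain bound to sulfur. Nothing measured follows a halogen being replaced by methoxy, so no step beyond the scatter is expected in this assay either way, and the estimate for compound 4 is 42%, between 28% and 58%, a step of a number 0.7 percentage points lower from compound 1 to compound 4 (within the scatter) that is expected to remain within the scatter.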

Compound 4, a percentage reported as inhibition, in the whole organism at one dose (the size of the read-out at that dose, not a potency): 34.3%
Estimate against measurement, compound 4: 7.7 percentage points above; measured number inside the range.
By their numbers in this assay, from the lowest: compounds 4, 1, 2 and 3 (each within the scatter of the next, the first and the last beyond it).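

In this assay, methoxy in place of chloro on the aromatic carbon para to a large group gives a number 8.4 percentage points lower from compound 1 to compound 4 (within the scatter), so this place takes a non-halogen group carrying a hydrogen-bond acceptor without a step that stands clear of the scatter. The other compounds showed only one halogen exchanged for another at this place, a number 6.3 percentage points higher from compound 2 to compound 3 (within the scatter), and with a different chain on the sulfur. No measurement bearing on why the 4-chlorophenyl to 4-methoxyphenyl change reads this way is available.

Open, from the compounds shown here alone, is whether an amine or a carboxylic acid at this place would give a step beyond the scatter. Also open, going by these compounds, is whether methoxy reads the same alongside a longer chain on the sulfur.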